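Replacing a substituted phenyl with pyridin-2-yl

A few compounds are considered here, and "the series" means these few. Any claim that something is new, unique, unknown or untested is made for them only; others in the source may bear on it.

Three compounds have been measured so far in a functional assay on MCF7 cells (Homo sapiens) for antiproliferative activity, read by MTT assay, with a stated time of 72 h (a lower number here means a stronger inhibitor, a higher number a weaker inhibitor), to date:

- compound 1 `Nc1nc(N)c2cc(CSC(=S)N3CCN(c4ccccc4)CC3)ccc2n1` gives 2950 nM
- compound 2 `Nc1nc(N)c2cc(CSC(=S)N3CCN(c4ccccc4F)CC3)ccc2n1` gives 4840 nM
- compound 3 `Nc1nc(N)c2cc(CSC(=S)N3CCN(c4ccc(C(F)(F)F)cc4)CC3)ccc2n1` gives 7400 nM

Compound 3 is separated from just one of the other two: a 2.5-fold higher number from compound 1 to compound 3 (0.40 log units; beyond the scatter) is a modest but real gap, whereas a 1.5-fold higher number from compound 2 to compound 3 (0.18 log units; within the scatter) is not.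

Compound 4 `Nc1nc(N)c2cc(CSC(=S)N3CCN(c4ccccn4)CC3)ccc2n1` makes a single change, with pyridin-2-yl in place of 4-(trifluoromethyl)phenyl on an amine nitrogen in a ring.

Among the measured compounds shown here, two measured steps bear on this. Starting from the unsubstituted phenyl, fluoro in place of hydrogen gave a 1.6-fold higher number from compound 1 to compound 2 (0.22 log units; within the scatter) and trifluoromethyl in place of hydrogen gave a 2.5-fold higher number from compound 1 to compound 3 (0.40 log units; beyond the scatter) as the result. Neither step lowered the number. Compound 4 loses the trifluoromethyl group, so a modest move to a lower number is expected, landing near compound 1 at 2950 nM on that scale. For the measured compounds named here, no measured compound carries pyridin-2-yl, which leaves this expectation uncertain.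

The expected change is a 2.1-fold lower number from compound 3 to compound 4 (0.33 log units; beyond the scatter) by this estimate. For compound 4 the estimated value is 3500 nM, with a likely range from 1500 nM to 8000 nM in this assay once tested.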

Compound 4, half-maximal inhibitory concentration: 5110 nM
Estimate against measurement, compound 4: 1.5-fold (0.16 log units) below, and the stated range covers the measured number.
By their numbers in this assay, from the lowest: compounds 1, 2, 4 and 3 (each within the scatter of the next, the first and the last beyond it).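

In this assay, pyridin-2-yl on this amine nitrogen in a ring cannot be told apart from any of the three phenyl groups measured so far: against 4-(trifluoromethyl)phenyl the step is (a 1.4-fold lower number from compound 3 to compound 4 (0.16 log units; within the scatter)), against 2-fluorophenyl it is (a 1.1-fold higher number from compound 2 to compound 4 (0.02 log units; within the scatter)), and against plain phenyl it is (a 1.7-fold higher number from compound 1 to compound 4 (0.24 log units; within the scatter)). The position therefore accepts a nitrogen in the aromatic ring, and with it a hydrogen-bond acceptor that the phenyl groups lack, without a change that stands clear of the scatter. Compound 4 also adds no step from compound 1 to a clearly lower number, so the plain phenyl remains unbeaten here, and no measurement available explains why the pyridin-2-yl result falls where it does.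

Going by these compounds, what stays open is whether a group of a different kind at this nitrogen, such as a benzyl group, a methoxyphenyl or a simple methyl, could give a number clearly lower than that of compound 1. A pyridin-2-yl carrying its own substituent, such as a chlorine or an amine, is also still to be seen.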